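Nitro in place of cyano: notes on the series

The source may hold more compounds than are shown below. What is called first, only, known or untested is meant among the compounds shown, and "the series" means these compounds.

Measured so far in a functional assay on DU-145 cells (Homo sapiens) for antiproliferative activity, read by propidium iodide staining, with a stated time of 96 h; on this read-out lower numbers stand for stronger inhibition and higher numbers for weaker inhibition
compound 1 `CC(O)(CSc1ccc(S(F)(F)(F)(F)F)cc1)C(=O)Nc1ccc(C#N)c(C(F)(F)F)c1` gives 27900 nM
compound 2 `CC(O)(CSc1cccc(S(F)(F)(F)(F)F)c1)C(=O)Nc1ccc(C#N)c(C(F)(F)F)c1` gives 32700 nM

With only these two numbers in hand, compound 1 has no clear rank. Its value and that of compound 2 lie within the scatter of each other, so this assay does not separate them.

The next compound to be measured is compound 3 `CC(O)(CSc1ccc(S(F)(F)(F)(F)F)cc1)C(=O)Nc1ccc([N+](=O)[O-])c(C(F)(F)F)c1`. It carries nitro in place of cyano on an aromatic carbon, ortho to a trifluoromethyl group and para to a large group, and the rest of the core of compound 1 stays the same: nitro in place of cyano on an aromatic carbon.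

Among the measured compounds shown here, no measured pair shows this change, so the data give no direct guide to its size or direction. The working expectation is therefore no step beyond the scatter in this assay, with a wide range to reflect that gap. The expected step is a 1.0-fold higher number from compound 1 to compound 3 (0.00 log units; within the scatter). For compound 3 the estimated value is 28000 nM, with an expected range from 11000 nM to 60000 nM.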

Compound 3, half-maximal inhibitory concentration: 13900 nM
Estimate against measurement, compound 3: 2.0-fold (0.30 log units) above; low and high end bracket the measured number.
By their numbers in this assay, from the lowest: compounds 3, 1 and 2 (each within the scatter of the next, the first and the last beyond it).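

Among the compounds shown here, the first measured pair for this change gives a 2.0-fold lower number from compound 1 to compound 3 (0.30 log units; within the scatter) in this assay, so this assay does not separate nitro from cyano on this aromatic carbon, ortho to a trifluoromethyl group and para to a large group. The earlier compounds shown here left this position unexplored, and this single pair now shows that, on the core of compound 1, the replacement produces no step beyond the scatter, in either direction. No measured evidence is available to explain how either group acts at this position.

Going by these compounds, the result comes from one pair on one core, so it remains open whether nitro in place of cyano would also stay within the scatter on the core of compound 2, and the step cannot be carried over to other assays or read-outs. On these data alone, it also remains open whether a clearer step would appear with a different group on the same aromatic carbon, such as an amine, a carboxylic acid or a bromine atom, with the rest of the core of compound 1 unchanged.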